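The source may hold more compounds than are shown below. What is called first, only, known or untested is meant among the compounds shown, and "the series" means these compounds.

In a functional assay on HT-29 cells (Homo sapiens) for inhibition, read by MTT assay, with a stated time of 72 h (on this read-out higher numbers stand for weaker inhibition and lower numbers for stronger inhibition), compound 3 (`COc1cc(Oc2cccc(Nc3ccccc3)c2)cc(OC)c1CNCc1ccc(F)cc1`) gives 2750 nM, within the scatter of compound 1 (`COc1ccc(CNCc2c(OC)cc(Oc3cccc(Nc4ccccc4)c3)cc2OC)cc1`) at 1890 nM. Compound 2 (`COc1ccc(CCCNCc2c(OC)cc(Oc3ccc(Nc4ccccc4)cc3)cc2OC)cc1`) gives 6890 nM, beyond the scatter of compound 3 on the higher side. Compound 4 (`COc1ccc(CCCNCc2c(OC)cc(Oc3cccc(Nc4ccccc4)c3)cc2OC)cc1`) differs from compound 3 by 2-(4-methoxyphenyl)ethyl in place of 4-fluorophenyl on a saturated chain carbon bound to an amine nitrogen. Among the compounds with values here, the one measured single-place step, a 1.5-fold higher number from compound 1 to compound 3 (0.16 log units; within the scatter), is fluoro in place of methoxy on an aromatic carbon and stayed within the scatter. Within the data shown here, no measured step covers the chain itself. Compound 2 carries the same 3-(4-methoxyphenyl)propyl group, but its core differs from that of compound 4, so it offers only weak guidance towards a higher number. A small rise, not beyond the scatter, is expected: a 1.3-fold higher number from compound 3 to compound 4 (0.10 log units; within the scatter). For compound 4 the estimate is 3500 nM, with an expected range of 1400 nM to 8000 nM.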

Compound 4, half-maximal inhibitory concentration: 3320 nM
Compound 4: middle estimate off by 1.1-fold (0.02 log units), on the high side, and the stated range covers the measured number.
By their numbers in this assay, from the lowest: compounds 1, 3 and 4 (each within the scatter of the next); then compound 2.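

In this assay, the place on the saturated chain carbon bound to the amine nitrogen accepts 3-(4-methoxyphenyl)propyl in place of 4-fluorobenzyl (a 1.2-fold higher number from compound 3 to compound 4 (0.08 log units; within the scatter)). Against the group of compound 1, the same chain also stays within the scatter (a 1.8-fold higher number from compound 1 to compound 4 (0.24 log units; within the scatter)), so compounds 1, 3 and 4 show no read-out difference at this place. No measured evidence bears on this result.

As far as these compounds go, whether a 5-phenylpentyl chain, or a carboxylic acid in place of the 4-methoxyphenyl, would move the number beyond the scatter stays open.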